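Replacing 1H-imidazol-4-yl with bromo in compound 3

A few compounds are considered here, and "the series" means these few. Any claim that something is new, unique, unknown or untested is made for them only; others in the source may bear on it.

In a functional assay on SW982 cells (Homo sapiens) for inhibition, read by MTT assay, with a stated time of 72 h (on this read-out higher numbers stand for weaker inhibition and lower numbers for stronger inhibition), compound 1 `COc1cc(OC)c(-c2cc(=O)c3ccc(O)cc3o2)cc1OC` reads > 150000 nM, which is a limit and not a number. Compound 2 `COc1cc(OC)c(OC)cc1/C=C/C(=O)c1cc(Cc2ccccc2)cc(Cc2ccccc2)c1` gives a true reading of 69900 nM. Compound 3 `COc1cc(OC)c(OC)cc1/C=C/C(=O)c1ccc(-c2c[nH]cn2)cc1` stands at > 150000 nM, again only a limit. Compound 4 `COc1cc(OC)c(OC)cc1/C=C/C(=O)c1ccc(Br)cc1` carries bromo in place of 1H-imidazol-4-yl on an aromatic carbon, para to a large group: bromo in place of 1H-imidazol-4-yl on an aromatic carbon. Among the compounds with values here, no pair of measured compounds isolates this change, so the expectation leans on compound 2, whose 69900 nM shows that a number can be read in this assay. A modest move towards stronger inhibition is expected, an estimated at least 2.1-fold lower number from compound 3 to compound 4 (0.33 log units; beyond the scatter). For compound 4 the estimated value is 70000 nM, with an expected range from 25000 nM to 150000 nM.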

Compound 4, half-maximal inhibitory concentration: 38200 nM
Beside the measured number, compound 4's estimate is 1.8-fold (0.26 log units) above it; the measured number falls inside the stated range.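

In this assay, on this aromatic carbon para to a large group, bromo in place of 1H-imidazol-4-yl gives an at least 3.9-fold lower number from compound 3 to compound 4 (0.59 log units; beyond the scatter). This is the only single-place comparison among the compounds shown, and it puts a true number where a limit stood. The size of the step stays open-ended, since the value of compound 3 is only a limit: the limit of > 150000 nM in this assay, at which 2 of the 4 values shown sit.

The compounds shown leave open whether bromo itself or the loss of 1H-imidazol-4-yl accounts for the step. As far as these compounds go, how a chloro group or an amine would read on this carbon also remains open.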